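This account rests on a few compounds, and the source may have more. Where it says the series, first, only, none or still open, it means among the compounds named here.

Compound 1 `CCON/C(=N\C1=NC(=O)C(=O)N1C(C)C)Nc1ccc(Cl)c(Cl)c1` reaches only a limit in an in vitro ADME assay on microsomes from liver (Mus musculus) for metabolic stability, read by LC-MS (a lower number here means that the compound disappears faster, a higher number that the compound lasts longer), > 1 h.
Compound 2 `C=CCON/C(=N\C1=NC(=O)C(=O)N1C(C)C)Nc1ccc(Cl)c(Cl)c1` likewise gives only a limit in this assay, > 1 h.

Compound 2 therefore stands where the numbers stop: its half-life in this assay is a limit, not a measured value, and the same holds for compound 1, so the step that the two limits leave unreadable from compound 1 to compound 2 cannot be read. For the measured compounds named here, the one piece of evidence on the measured pair is the limit of > 1 h in this assay, at which 2 of the 2 values shown sit, which fixes nothing about the size of any change.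

Compound 3 `CC(C)N1C(=O)C(=O)N=C1/N=C(\NOCc1ccccc1)Nc1ccc(Cl)c(Cl)c1` differs from compound 2 by phenyl in place of vinyl on a saturated chain carbon bound to an oxygen on an unsaturated carbon. Going by the values given here, no measured step bears on this exchange: the only step recorded, from compound 1 to compound 2, is unreadable, and it concerns a different group at the same place. What is known is that both measured compounds sit at the limit of this assay. On that basis compound 3 is expected to behave like its neighbours, with a step that the limit leaves unreadable from compound 2 to compound 3 that is expected to lie within the scatter. Compound 3 is estimated at 1.5 h in this assay, within the range 0.5 h to 4 h.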

Compound 3, half-life: > 1 h
Compound 3 gave a limit, no number (the forecaster's own chance of this, stated with the estimate: 55%); the middle value lies beyond the limit too.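

Compound 3 also gives only a limit in this assay, > 1 h. For the compounds shown here, no step among compound 1, compound 2 and compound 3 can therefore be read: the limit of > 1 h in this assay, at which 3 of the 3 values shown sit. The compounds shown leave open how long each of the three actually lasts in this assay, and whether methyl, vinyl or phenyl at this place changes the half-life at all.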